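A few compounds are considered here, and "the series" means these few. Any claim that something is new, unique, unknown or untested is made for them only; others in the source may bear on it.

In a functional assay on BXPC-3 cells (Homo sapiens) for cytotoxicity, read by MTT assay, with a stated time of 72 h (a lower number here means a stronger inhibitor, a higher number a weaker inhibitor), compound 3 `O=C1C(Nc2ccc(-c3ccccc3)cc2)=CC(=O)c2ncncc21` gives 500 nM. Of the three measured compounds it holds the lowest number: compound 2 `COc1ccc(NC2=CC(=O)c3ncncc3C2=O)cc1` gives 1700 nM, and compound 1 `O=C1C(Nc2ccc(Oc3ccccc3)cc2)=CC(=O)c2ncncc21` gives 3600 nM. Both measured steps leading to compound 3 run the same way, a 7.2-fold lower number from compound 1 to compound 3 (0.86 log units; beyond the scatter) and a 3.4-fold lower number from compound 2 to compound 3 (0.53 log units; beyond the scatter), while between the other two a 2.1-fold lower number from compound 1 to compound 2 (0.33 log units; beyond the scatter). All three steps exchange the whole group that sits on the aromatic carbon of the shared core's aniline ring.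

Compound 4 `Nc1ccc(-c2ccc(NC3=CC(=O)c4ncncc4C3=O)cc2)cc1` differs from compound 3 in one place: amino in place of hydrogen on an aromatic carbon. Among the measured compounds shown here, no measured step touches this part of the molecule; every step so far replaced one group by another, and none added anything to a phenyl that was kept. The measured data therefore give no direct guide to this change. For the measured compounds named here, what they do show is that compound 4 keeps the phenyl of compound 3, the arrangement with the lowest number so far, and only adds to it.

For compound 4 the expected step in this assay is a 1.1-fold lower number from compound 3 to compound 4 (0.05 log units; within the scatter), that is, nothing beyond the scatter. The estimate for compound 4 is 450 nM, with a range from 150 nM to 1300 nM.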

Compound 4, half-maximal inhibitory concentration: 3500 nM
Estimate against measurement, compound 4: 7.8-fold (0.89 log units) below; the measured number lies above the stated range.
By their numbers in this assay, from the lowest: compound 3; then compound 2; then compounds 4 and 1 (each within the scatter of the next).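

In this assay, among the compounds shown here, the phenyl of compound 3 turns out to be sensitive to even a small addition: amino in place of one hydrogen gives a 7.0-fold higher number from compound 3 to compound 4 (0.85 log units; beyond the scatter) and so costs about as much as the larger exchange that gave a 7.2-fold lower number from compound 1 to compound 3 (0.86 log units; beyond the scatter) in the earlier compounds. The low number of compound 3 therefore belongs to the plain phenyl and does not carry over to 4-aminophenyl, as the remaining steps show: there is a 2.1-fold higher number from compound 2 to compound 4 (0.31 log units; beyond the scatter) so that methoxy now holds the lower number, and there is a 1.0-fold lower number from compound 1 to compound 4 (0.01 log units; within the scatter) so that 4-aminophenyl and phenoxy cannot be told apart. No measurement at hand explains why this one added group has so large an effect.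

The compounds shown leave open whether the rise in number is tied to the amino group itself or would follow any addition in this place on the phenyl. A hydroxyl, a methyl or a fluorine in the same place, or a dimethylamino group in place of the amino, would help to separate these two readings.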